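Hydroxy to methoxy on compound 1

This account rests on a few compounds, and the source may have more. Where it says the series, first, only, none or still open, it means among the compounds named here.

In a functional assay on SKW 6.4 cells (Homo sapiens) for cytotoxicity (a higher number here means a weaker inhibitor, a lower number a stronger inhibitor), compound 1 (`C/C=C/C1=C(CO)[C@H](O)[C@H]2O[C@H]2C1=O`) reads > 80000 nM as a limit of the assay and not a number. Compound 2 (`O=C1C(/C=C/c2ccccc2)=C(CO)[C@H](O)[C@H]2O[C@@H]12`) gives 30000 nM in this assay as its measured value. Compound 3 (`C/C=C/C1=C(CO)[C@H](OC)[C@H]2O[C@H]2C1=O`) has methyl in place of hydrogen on an oxygen on a saturated carbon and otherwise matches compound 1. Within the data shown here, the only measured step is an at least 2.6-fold lower number from compound 1 to compound 2 (0.42 log units; beyond the scatter) with phenyl in place of methyl on the chain, a different change that sets no size here. No step beyond the scatter is therefore expected in this assay, and the expected step is a number no higher from compound 1 to compound 3 (the limit leaves the size open) in size. For compound 3 the estimated value is 80000 nM with a range of 30000 nM to 200000 nM as the likely span.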

Compound 3, half-maximal inhibitory concentration: > 80000 nM
Compound 3 gave a limit, no number; the forecaster's own chance of this, stated with the estimate: 65%; the middle value lies on the limit itself.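

Compound 1 and compound 3 both stop at a limit of the assay and not at a number, so no step between them can be read: the limit of > 80000 nM in this assay, at which 2 of the 3 values shown sit.

The compounds shown leave open whether hydroxy to methoxy changes the read-out in this assay at all.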